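Growth inhibition notes: compound 2 to compound 4

This account rests on a few compounds, and the source may have more. Where it says the series, first, only, none or still open, it means among the compounds named here.

In an ADME assay on HEK-293T cells (Homo sapiens) for inhibition, read by CCK-8 assay, with a stated time of 48 h, tested at 20 uM (a lower number here means less inhibition of growth, a higher number more inhibition of growth at the concentration tested), compound 2 (`COc1ccc(Cc2nnc(NC(=O)/C(C#N)=C/c3ccccc3OS(=O)(=O)c3ccccc3[N+](=O)[O-])s2)cc1`) gives 18% and compound 1 (`COc1ccc(Cc2nnc(NC(=O)/C(C#N)=C/c3ccccc3OS(=O)(=O)c3ccc([N+](=O)[O-])cc3)s2)cc1`) gives 17% (within the scatter of each other), while compound 3 (`COc1ccc(Cc2nnc(NC(=O)/C(C#N)=C/c3ccccc3OS(=O)(=O)c3ccc(F)cc3)s2)cc1`) gives 6% (beyond the scatter of both). Compound 4 (`N#C/C(=C\c1ccccc1OS(=O)(=O)c1ccccc1[N+](=O)[O-])C(=O)Nc1nnc(Cc2cccc3ccccc23)s1`) departs from compound 2 as follows: naphthalen-1-yl in place of 4-methoxyphenyl on a saturated chain carbon bound to an aromatic carbon. Within the data shown here, all three measured compounds carry 4-methoxyphenyl there, so no measured step tests this place. The measured steps change only the group on the sulfonyl sulfur: a number 1 percentage points higher from compound 1 to compound 2 (within the scatter) and a number 12 percentage points lower from compound 2 to compound 3 (beyond the scatter) and also a number 11 percentage points lower from compound 1 to compound 3 (beyond the scatter) and none is more than modest. With nothing pointing in either direction, no step beyond the scatter is expected in this assay for this change. The estimated step is no change at the digits printed from compound 2 to compound 4 (within the scatter) and it rests on thin evidence. Compound 4 is expected at 18% (estimated range 6% to 32%).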

Compound 4, percent growth inhibition at one concentration: "not toxic" (no number reported)
For compound 4 the study gives words and no number; the estimate stays without a comparison.
By their numbers in this assay, from the lowest: compound 3; then compounds 1 and 2 (each within the scatter of the next).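

In this assay, among these compounds, compound 4 is reported only in words, as "not toxic", so no step from compound 2 to compound 4 can be read. The compounds shown leave open what naphthalen-1-yl in place of 4-methoxyphenyl does to growth inhibition, and no evidence here bears on this result.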